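The compounds below may be only part of what the source reports. "The series", "measured", "known", "first", "only" and "open" are said of these compounds alone.

Measured compounds: compound 1 `CCCS(=O)(=O)N1CC=C(c2ccc3c(c2)CC(C2CCN(S(=O)(=O)CCC)CC2)O3)CC1` and compound 2 `CCCc1cnc(N2CCC(C3Cc4cc(C5=CCN(S(=O)(=O)CCC)CC5)ccc4O3)CC2)nc1`.

In a functional assay on HEK293 cells with Glucose-dependent insulinotropic receptor (Homo sapiens) as the target, read by cAMP accumulation, with a stated time of 60 min (on this read-out lower numbers stand for smaller maximal responses and higher numbers for larger maximal responses), compound 1 gives 43%. In this assay compound 2 gives 107%. Compound 2 thus stands highest of the two measured numbers, its nearest neighbour being compound 1, with a number 64 percentage points higher from compound 1 to compound 2 (beyond the scatter). Compound 3 `CCCc1cnc(N2CCC(C3Cc4cc(N5CCN(S(=O)(=O)CCC)CC5)ccc4O3)CC2)nc1` differs from compound 2 by a group of 12 heavy atoms (7 carbon, 2 nitrogen, 2 oxygen, 1 sulfur; one six-membered non-aromatic ring with 2 hetero atoms) in place of a group of 12 heavy atoms (8 carbon, 1 nitrogen, 2 oxygen, 1 sulfur; one six-membered non-aromatic ring with 1 hetero atom), on an aromatic carbon. Going by the values given here, the one measured step changes the substituent on the amine nitrogen in a ring, not the group on the aromatic carbon, so no measured step bears directly on this change. Compound 3 is therefore expected to stay close to compound 2, with a number 7 percentage points lower from compound 2 to compound 3 (within the scatter), no step beyond the scatter, and an estimated 100% in a range from 60% to 130%.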

Compound 3, largest response reached (Emax), in percent of the reference or control that the assay uses: 74%
Estimate against measurement, compound 3: 26 percentage points above; the range from low to high includes it.
By their numbers in this assay, from the lowest: compound 1; then compound 3; then compound 2.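

The earlier step concerned only the amine nitrogen in a ring; this one shows that the group on the aromatic carbon also matters in this assay. With the 5-propylpyrimidin-2-yl group kept, placing 4-(propylsulfonyl)piperazin-1-yl there gives a number 33 percentage points lower from compound 2 to compound 3 (beyond the scatter) even though both groups have the same count of heavy atoms. Nothing available explains this drop.

As far as these compounds go, whether the same exchange would have a similar effect with propylsulfonyl on the ring nitrogen remains open. So does how a morpholine ring at this aromatic carbon would compare.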